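The source may report more compounds than this note shows. Statements on the series, on what has been measured and on what is new or still open speak of the compounds shown alone.

Working notes on the series. In an ADME assay on GES1 cells (Homo sapiens) for inhibition, read by MTT assay, with a stated time of 72 h (on this read-out higher numbers stand for weaker inhibition and lower numbers for stronger inhibition), compound 1 `Cc1cc(Nc2cc(-c3ccccc3)[nH]n2)n2nc(SCC3CCCCC3)nc2n1` reads > 50000 nM, which is a limit. Compound 2 `Cc1cc(Nc2cc(-c3ccccc3)[nH]n2)n2nc(SCc3cccc(Br)c3)nc2n1` reads > 50000 nM, which is also a limit. That places compound 2 at the limit of > 50000 nM in this assay, at which 2 of the 3 values shown sit, so it has no numerical position in the series. For the measured compounds named here, compound 3 `Cc1cc(Nc2ccn(Cc3ccc(F)cc3)n2)n2nc(SCc3ccc(Br)cc3)nc2n1` gives a true number, 40500 nM, but no measured single-place step connects it with compound 2.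

The step under consideration leads to compound 4 `C=CCSc1nc2nc(C)cc(Nc3cc(-c4ccccc4)[nH]n3)n2n1`. The change is vinyl in place of 3-bromophenyl on a saturated chain carbon bound to a sulfur. Cut one bond further out, the same change reads as 3-bromobenzyl to allyl.

Going by the values given here, one measured step bears on this place: a step that the two limits leave unreadable from compound 1 to compound 2. It offers no size to carry over and no direction. With only a step that the two limits leave unreadable from compound 1 to compound 2 to go on, no step beyond the scatter is expected in this assay, and the reading may well be a limit again. The expected step is a number no higher from compound 2 to compound 4 (the limit leaves the size open), and this is an estimate only. For compound 4 the expected value is 50000 nM, with an estimated range of 20000 nM to 100000 nM.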

Compound 4, half-maximal inhibitory concentration: > 50000 nM
Compound 4: no number, only a limit (the forecaster's own chance of this, stated with the estimate: 70%); the middle value sits exactly at the limit.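

In this assay, compound 4 reads > 50000 nM, which is a limit. The steps joining compound 4 to compound 1 and compound 2 therefore cannot be read: the limit of > 50000 nM in this assay, at which 3 of the 4 values shown sit.

Left open is whether cyclohexyl, 3-bromophenyl and vinyl on a saturated chain carbon bound to a sulfur differ at all in this assay.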